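The source may report more compounds than this note shows. Statements on the series, on what has been measured and on what is new or still open speak of the compounds shown alone.

Working notes on the series. In a physicochemical assay for lipophilicity, at pH 7.4 (on this read-out higher numbers stand for higher lipophilicity and lower numbers for lower lipophilicity), compound 2 (`Cc1cc(-c2c(C)nn(C)c2C)ccc1-c1nnc(N(C)Cc2ccc3ncc(-c4ccccc4)n3c2)o1`) gives 5.3, the highest of the two numbers in hand. The nearest value belongs to compound 1 (`CN(Cc1ccc2nccn2c1)c1nnc(-c2ccc(C3CC3)cc2)o1`), which in this assay gives 3.5, a gap beyond the scatter. Among the measured compounds shown here, the two compounds differ in several places at once, so no single-point step between measured compounds is available to calibrate the next change.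

Compound 3 (`Cc1cc(-c2c(C)nn(C)c2C)ccc1-c1nnc(N(C)Cc2ccc3ncc(-c4cnn(CCN(C)C)c4)n3c2)o1`) has not yet been measured. It is derived from compound 2 by one change: 1-(2-(dimethylamino)ethyl)-1H-pyrazol-4-yl in place of phenyl on an aromatic carbon. With no measured step of this kind in the series, the expectation rests on the structures alone. The step expected in this assay, a number 1.80 log units lower from compound 2 to compound 3 (beyond the scatter), is a drop beyond the scatter, of a size comparable to the gap between compound 1 and compound 2. For compound 3 the value expected in this assay is estimated at 3.5, with a range from 2.6 to 4.3.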

Compound 3, distribution coefficient: 3.5
Compound 3: middle estimate and measured number agree at the digits printed; low and high end bracket the measured number.
By their numbers in this assay, from the lowest: compounds 1 and 3 (each within the scatter of the next); then compound 2.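

In this assay, among the compounds shown here, the first single-place step is now available: 1-(2-(dimethylamino)ethyl)-1H-pyrazol-4-yl in place of phenyl gives a number 1.80 log units lower from compound 2 to compound 3 (beyond the scatter) and is classed as large. This shows that one exchange at this aromatic carbon, with the rest of compound 2 kept, is enough to move the read-out well beyond the scatter, even though the entering group has 10 heavy atoms against 6 for phenyl and brings 3 hydrogen-bond acceptors where phenyl has 0. No measurement in hand explains the size of this step.

Open, as far as these compounds go, is how the step divides between the pyrazole ring and the dimethylaminoethyl chain, which a 1-methyl-1H-pyrazol-4-yl group at the same place would separate. Also open, from the compounds shown here alone, is whether a morpholine or a carboxylic acid at the end of that chain would give a step of similar size.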